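This account rests on a few compounds, and the source may have more. Where it says the series, first, only, none or still open, it means among the compounds named here.

Of the compounds shown here, three have been measured in an in vitro ADME assay on microsomes from liver (Homo sapiens) for metabolic stability, tested at 0.2 uM; on this read-out higher numbers stand for fast clearance and lower numbers for slow clearance. Compound 1 `COCCOCCCCc1[nH]c2ccccc2c(=O)c1C` gives 45 mL/min/kg, compound 2 `Cc1c(COc2cccc(OCC3CCOCC3)c2)[nH]c2ccccc2c1=O` gives 214 mL/min/kg, and compound 3 `O=c1cc(COc2cccc(OCC3CCOCC3)c2)[nH]c2ccccc12` gives 78 mL/min/kg. Compound 3 therefore lies within the scatter of compound 1 and well short of compound 2. The next compound to be measured, compound 4 `O=c1c(Cl)c(COc2cccc(OCC3CCOCC3)c2)[nH]c2ccccc12`, differs from compound 3 in one place: chloro in place of hydrogen on an aromatic carbon. The carbon involved is the one that bears methyl in compound 2, so one measured step bears on the change: a 2.7-fold lower number from compound 2 to compound 3 (0.44 log units; beyond the scatter), modest but beyond the scatter. Read in reverse, this step suggests that a group on this carbon can go with a higher number. For the measured compounds named here, it is only a single pair, however, and no chloro compound has yet been measured. The expected step is a 1.7-fold higher number from compound 3 to compound 4 (0.22 log units; within the scatter), upward but smaller than the step seen with methyl. For compound 4 the estimated clearance is 130 mL/min/kg, with an expected range from 65 mL/min/kg to 260 mL/min/kg.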

Compound 4, clearance: 460 mL/min/kg
For compound 4 the middle estimate is 3.5-fold (0.55 log units) below the measured one; the whole stated range lies below it.
By their numbers in this assay, from the lowest: compounds 1 and 3 (each within the scatter of the next); then compound 2; then compound 4.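

In this assay chloro in place of hydrogen on this aromatic carbon gives a 5.9-fold higher number from compound 3 to compound 4 (0.77 log units; beyond the scatter) and so shows that a higher number with a group on this carbon is not confined to methyl. The two groups do not match each other here: chloro in place of methyl gives a 2.1-fold higher number from compound 2 to compound 4 (0.33 log units; beyond the scatter) and thus the number depends on which group is present, not only on hydrogen being replaced. Among these three compounds, which differ only on this carbon, compound 3 with hydrogen has the lowest number, and its steps to both others lie beyond the scatter.

Going by these compounds, whether fluoro, methoxy or an amine on this carbon would also go with a higher number remains open. The compounds shown offer no measured basis for explaining these steps.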